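Working notes: fluoro added on the fluorophenyl ring

This account rests on a few compounds, and the source may have more. Where it says the series, first, only, none or still open, it means among the compounds named here.

Within the data shown here, the three measured members share one core and differ only in the substituent on the amide-type nitrogen at the far end of that core: compound 1 is `CCNC(=O)N1CCC(Oc2cc3nccc(Oc4ccc(NC(=O)NN5C(=O)CSC5c5ccc(F)cc5)cc4)c3cc2OC)CC1`, compound 2 is `COc1cc2c(Oc3ccc(NC(=O)NN4C(=O)CSC4c4ccc(F)cc4)cc3)ccnc2cc1OC1CCN(C(=O)NC(C)C)CC1` and compound 3 is `COc1cc2c(Oc3ccc(NC(=O)NN4C(=O)CSC4c4ccc(F)cc4)cc3)ccnc2cc1OC1CCN(C(=O)NCc2ccccc2)CC1`. In a functional assay on HT-29 cells (Homo sapiens) for inhibition, read by MTT assay (a lower number here means a stronger inhibitor, a higher number a weaker inhibitor), compound 1 gives 2250 nM, compound 2 gives 860 nM and compound 3 gives 6600 nM. Compound 2 stands lowest of the three numbers, and both steps away from it, a 2.6-fold lower number from compound 1 to compound 2 (0.42 log units; beyond the scatter) read in reverse and a 7.7-fold higher number from compound 2 to compound 3 (0.89 log units; beyond the scatter), lie beyond the scatter; the step of a 2.9-fold higher number from compound 1 to compound 3 (0.47 log units; beyond the scatter) is also beyond the scatter.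

Compound 4 is `COc1cc2c(Oc3ccc(NC(=O)NN4C(=O)CSC4c4ccc(F)c(F)c4)cc3)ccnc2cc1OC1CCN(C(=O)NC(C)C)CC1`. It differs from compound 2 by fluoro in place of hydrogen on an aromatic carbon; read one bond further out, the change is 4-fluorophenyl to 3,4-difluorophenyl. Among the measured compounds shown here, none of the measured steps touches this ring: all three sit on the amide-type nitrogen, so they give no basis for a direction or a size here. With nothing in the series bearing on the change, the step of no change at the digits printed from compound 2 to compound 4 (within the scatter) is expected to stay within the scatter. Compound 4 is estimated at 860 nM, with a range from 400 nM to 1900 nM.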

Compound 4, half-maximal inhibitory concentration: 1060 nM
Estimate against measurement, compound 4: 1.2-fold (0.09 log units) below; the range from low to high includes it.
By their numbers in this assay, from the lowest: compounds 2 and 4 (each within the scatter of the next); then compound 1; then compound 3.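

In this assay, among these compounds, this is the first measured change on the fluorophenyl ring of the shared core: going from 4-fluorophenyl to 3,4-difluorophenyl gives a 1.2-fold higher number from compound 2 to compound 4 (0.09 log units; within the scatter) and so leaves the number within the scatter. With the isopropyl group held in place on the amide-type nitrogen, a second fluoro on this aromatic carbon, ortho to a fluoro group and meta to a large group, therefore shows no readable effect, whereas all three steps on that nitrogen lie beyond the scatter. No supporting measurement accompanies this pair, and the result stands without an explanation.

From the compounds shown here alone, it remains open whether a chloro, methoxy, trifluoromethyl or amine group on the same aromatic carbon would also stay within the scatter, or whether moving the added fluoro elsewhere on the ring would do so. Going by these compounds, it is also open whether the 3,4-difluorophenyl ring would give the same flat step with the ethyl group of compound 1 or the benzyl group of compound 3 on the amide-type nitrogen.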